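A few compounds are considered here, and "the series" means these few. Any claim that something is new, unique, unknown or untested is made for them only; others in the source may bear on it.

Measured compounds:
Compound 1, `N#C/C(=C\c1c(F)c(F)c(F)c(F)c1F)C(=O)c1c[nH]c2ccccc12`, in a functional assay on DU-145 cells (Homo sapiens) for inhibition, read by MTT assay, with a stated time of 72 h (a higher number here means a weaker inhibitor of growth, a lower number a stronger inhibitor of growth), gives 30000 nM.
Compound 2, `COc1ccc(CNC(=O)/C(C#N)=C/c2ccc[nH]2)cc1`, in this assay gives > 50000 nM.

The value for compound 2 is not a number but a limit of the assay, (the limit of > 50000 nM in this assay, at which 1 of the 2 values shown sits). Compound 2 therefore stands at the weak end of what this assay can report. Compound 3, `COc1ccc(CNC(=O)/C(C#N)=C/c2ccc(C)cc2)cc1`, differs from compound 2 by 4-methylphenyl in place of 1H-pyrrol-2-yl on a double-bonded chain carbon bound to a double-bonded chain carbon. Within the data shown here, no measured pair separated by this change exists, so its size and direction cannot be read from the data. Compound 1, built on a different core, gives 30000 nM, also weak. Compound 3 is expected to stay weak, with an estimate of 45000 nM and a range from 12000 nM to 150000 nM. The expected step is an at least 1.1-fold lower number from compound 2 to compound 3 (0.04 log units; that floor lies within the scatter), not beyond the scatter.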

Compound 3, concentration for 50% growth inhibition: 34000 nM
The estimate for compound 3 lay 1.3-fold (0.12 log units) above the measured number, within the range that was stated.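

Among these compounds, replacing 1H-pyrrol-2-yl with 4-methylphenyl on a double-bonded chain carbon bound to a double-bonded chain carbon can now be given a first reading in this assay: an at least 1.4-fold lower number from compound 2 to compound 3 (0.16 log units; that floor lies within the scatter). The value of compound 2, > 50000 nM, is a limit of the assay and not a number. Compound 3 gives a real number, but the true size of this step stays unknown, and the change cannot be said to go beyond the scatter, because compound 2 sits at the limit: the limit of > 50000 nM in this assay, at which 1 of the 3 values shown sits.

Still open, going by these compounds, is whether an amine or a carboxylic acid in place of 4-methylphenyl at this same carbon would shift the growth read-out clearly. Among the compounds shown here, compound 1 differs from compound 2 and compound 3 in more than one place, so no step to it can be read.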